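The source may report more compounds than this note shows. Statements on the series, on what has been measured and on what is new or still open speak of the compounds shown alone.

Measured so far:
compound 1 `COC[C@H]1CN(c2ccn(C)c2)C(=O)O1` — 170000 nM
compound 2 `Cn1ccc(N2C[C@H](CN=[N+]=[N-])OC2=O)c1` — 360000 nM

In an assay for inhibition of Amine oxidase [flavin-containing] B (Bos taurus), read by fluorescence, with a stated time of 30 min (a higher number here means a weaker inhibitor, a lower number a stronger inhibitor), compound 2 gives 360000 nM, the higher of the two numbers available; compound 1 is the nearest neighbour, and the step of a 2.1-fold higher number from compound 1 to compound 2 (0.33 log units; beyond the scatter) is modest but beyond the scatter.

The next compound, compound 3 `Cn1ccc(N2C[C@H](CN)OC2=O)c1`, is not yet measured in this assay. It differs from compound 2 by amino in place of azido on a saturated chain carbon bound to a saturated ring carbon. Going by the values given here, no measured step covers this exchange: the only step in hand, a 2.1-fold higher number from compound 1 to compound 2 (0.33 log units; beyond the scatter), concerns a different group at the same place and shows that a change at this position moves the number only modestly. The same size of effect is therefore taken as the guide, with no firm direction.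

Compound 3 is expected to give about 250000 nM in this assay, between 100000 nM and 700000 nM, a step of a 1.4-fold lower number from compound 2 to compound 3 (0.16 log units; within the scatter) estimated from compound 2 that may well lie within the scatter.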

Compound 3, inhibition constant: 180000 nM
For compound 3 the middle estimate is 1.4-fold (0.14 log units) above the measured one; the range from low to high includes it.
By their numbers in this assay, from the lowest: compounds 1, 3 and 2 (each within the scatter of the next, the first and the last beyond it).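

In this assay, the swap of azidomethyl for aminomethyl stays within the scatter (a 2.0-fold lower number from compound 2 to compound 3 (0.30 log units; within the scatter)), although azido, with 3 heavy atoms and 0 hydrogen-bond donors, gives way to amino, with 1 heavy atom and 1 hydrogen-bond donor. Amino and methoxy on this saturated chain carbon also read alike (a 1.1-fold higher number from compound 1 to compound 3 (0.02 log units; within the scatter)), so the only step beyond the scatter among these compounds remains the one from methoxy to azido, and the position now looks tolerant of all three groups within a narrow band of values. Nothing available explains this flat response.

Going by these compounds, whether a carboxylic acid, an acetamide or a longer chain at this place would move the number further remains open. The compounds shown also leave open whether any change to the shared core would have a larger effect than these exchanges.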